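The compounds below may be only part of what the source reports. "The series", "measured", "known", "first", "only" and "open" are said of these compounds alone.

Compound 1, `FC(F)(F)c1ccc(-c2ccc3c(NCCCNCc4ccco4)ccnc3c2)cc1`, was tested in an ADME assay on HepG2 cells (Homo sapiens) for cytotoxicity, read by luminescence, CellTiter-Glo and ATP content, with a stated time of 72 h (a higher number here means that more compound is needed for the effect, a lower number that less compound is needed), where compound 1 gives 3470 nM. Of the two numbers recorded, this is the higher, but its only companion lies within the usual scatter: compound 2, `COc1cccc(CNCCCNc2ccnc3cc(Cc4cccc(C(F)(F)F)c4)ccc23)c1O`, gives 1720 nM in this assay, and the two compounds share a three-carbon chain linking the core to a benzylic amine, though the rest of each molecule is different, so the pair allows no statement of order.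

The account now turns to compound 3, `c1ccc(-c2ccc3c(NCCCNCc4ccco4)ccnc3c2)cc1`, which has not yet been measured in this assay. Its difference from compound 1 is a single one, (hydrogen in place of trifluoromethyl on an aromatic carbon). Within the data shown here, no measured pair in this set shows what such a change does here, so the expectation rests on the change itself and on compound 1 alone. A step from compound 1 to compound 3 of a 1.6-fold higher number from compound 1 to compound 3 (0.20 log units; within the scatter) is expected, a modest rise in the number or none beyond the scatter. Compound 3 is therefore estimated at 5500 nM, with a range from 2000 nM to 16000 nM.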

Compound 3, half-maximal effective concentration: 5920 nM
The estimate for compound 3 lay 1.1-fold (0.03 log units) below the measured number; the measured number falls inside the stated range.
By their numbers in this assay, from the lowest: compounds 2, 1 and 3 (each within the scatter of the next, the first and the last beyond it).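

In this assay, the exchange of trifluoromethyl for hydrogen on an aromatic carbon, para to a large group, gives a 1.7-fold higher number from compound 1 to compound 3 (0.23 log units; within the scatter) and so stays inside the range of repeated measurement. Among these compounds, this is the first comparison here in which only one place differs, and it shows that, in this setting, taking away the whole group, with its carbon and three fluorine atoms, leaves the number without a change that can be told from scatter: going from 4-(trifluoromethyl)phenyl to phenyl does not separate the two compounds. Nothing available bears on the reason for this result, and a single pair of this kind gives no direction for the position.

The compounds shown leave open whether another group at this carbon, such as an amine, a carboxylic acid or a methoxy group, would move the number beyond the scatter. They also leave open whether the same exchange would stay as small if the chain or the amine end of compound 1 were different.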